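Compound 2 to compound 3: chloro replaces methyl

The source may report more compounds than this note shows. Statements on the series, on what has been measured and on what is new or still open speak of the compounds shown alone.

In a functional assay on A549 cells (Homo sapiens) for antiproliferative activity, read by MTT assay, with a stated time of 48 h (a lower number here means a stronger inhibitor, a higher number a weaker inhibitor), compound 1 (`COc1ccccc1-n1cc(COC(=O)/C(C)=C/CC/C(C)=C/CC/C(C)=C/CC[C@@H]2[C@@]3(C)CCC(=O)C(C)(C)[C@H]3CC[C@@]2(C)O)nn1`) gives > 150000 nM which is a limit and no number. Compound 2 (`C/C(=C\CC/C(C)=C/CC[C@@H]1[C@@]2(C)CCC(=O)C(C)(C)[C@H]2CC[C@@]1(C)O)CC/C=C(\C)C(=O)OCc1cn(-c2cccc(C)c2)nn1`) gives > 150000 nM which is again a limit and so marks its only standing. Within the data shown here, the sole measured step is a step that the two limits leave unreadable from compound 1 to compound 2 and the record holds just the limit of > 150000 nM in this assay, at which 2 of the 2 values shown sit, as its evidence. Compound 3 (`C/C(=C\CC/C(C)=C/CC[C@@H]1[C@@]2(C)CCC(=O)C(C)(C)[C@H]2CC[C@@]1(C)O)CC/C=C(\C)C(=O)OCc1cn(-c2cccc(Cl)c2)nn1`) carries chloro in place of methyl on an aromatic carbon with chloro in place of methyl on an aromatic carbon. Compound 2 offers no readable step to scale from, so no shift beyond the scatter is expected in this assay here. The estimate amounts to a number no higher from compound 2 to compound 3 (the limit leaves the size open) as the expected step. Compound 3 is expected near 150000 nM within an estimated range of 60000 nM to 300000 nM and may well appear only as a limit again.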

Compound 3, half-maximal inhibitory concentration: 147000 nM
Estimate against measurement, compound 3: 1.0-fold (0.01 log units) above; low and high end bracket the measured number.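

In this assay compound 3 gives a number, 147000 nM, so the 3-chlorophenyl group brings the first read-out in this series that is not a limit: the limit of > 150000 nM in this assay, at which 2 of the 3 values shown sit. Even so, the steps read only as an at least 1.0-fold lower number from compound 2 to compound 3 (0.00 log units; that floor lies within the scatter) and an at least 1.0-fold lower number from compound 1 to compound 3 (0.00 log units; that floor lies within the scatter), so neither change is shown to go beyond the scatter. The compounds shown leave open whether an amine or a carboxylic acid on this aromatic carbon would give a clearly lower number. They also leave open whether chloro elsewhere on the ring would do so.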